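The compounds below may be only part of what the source reports. "The series", "measured", "known", "first", "only" and "open" are said of these compounds alone.

Compound 1, `CCOc1cc(C(Nc2ccc3cnccc3c2)C(=O)NS(=O)(=O)c2ccccc2)ccc1OC(C)C`: > 5000 nM
Compound 2, `CCOc1cc(C(Nc2ccc3c(N)nccc3c2)C(=O)NS(=O)(=O)c2cccc(N)c2)ccc1OC(C)C`: > 5000 nM
Compound 3, `CCOc1cc([C@@H](Nc2ccc3c(N)nccc3c2)C(=O)NS(=O)(=O)c2cccc(S(N)(=O)=O)c2)ccc1OC(C)C`: > 5000 nM

All three compounds share one core and were tested in an assay on isolated protein for inhibition of Trypsin (Homo sapiens); on this read-out higher numbers stand for weaker inhibition and lower numbers for stronger inhibition. Compound 2 gives > 5000 nM, which is a limit of the assay and not a measured number. Compound 1 gives > 5000 nM, likewise a limit. Compound 3 gives > 5000 nM, again a limit. Every value shown therefore sits at the limit of > 5000 nM in this assay, at which 3 of the 3 values shown sit, so compound 2 cannot be placed above or below its neighbours; all that is known is that none of them inhibits strongly enough to be measured here.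

Compound 4, `CCOc1cc(C(Nc2ccc3c(N)nccc3c2)C(=O)NS(=O)(=O)c2ccc(O)cc2)ccc1OC(C)C`, is the next compound. Its change from compound 2 is 4-hydroxyphenyl in place of 3-aminophenyl on a sulfonyl sulfur. Going by the values given here, since no step between measured compounds is available, there is nothing that shows this kind of exchange moving the read-out in either direction. The expectation for compound 4 in this assay is a value of 8000 nM, with a range from 3000 nM to 30000 nM, most likely again reported only as a limit. This expected step is a step that the limit leaves unreadable from compound 2 to compound 4, nothing beyond the scatter.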

Compound 4, inhibition constant: > 5000 nM
Compound 4 was reported as a limit; the forecaster's own chance of this, stated with the estimate: 85%; the middle value is on the limit's open side.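

Compound 2 and compound 4 are both reported only as limits, so swapping 3-aminophenyl for 4-hydroxyphenyl gives no step that can be read: the limit of > 5000 nM in this assay, at which 4 of the 4 values shown sit.

The compounds shown leave open how strongly any of them inhibits in this assay, and whether this exchange changes that inhibition at all.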